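Difluorophenyl to Dimethylphenyl on the Amide Nitrogen

This account rests on a few compounds, and the source may have more. Where it says the series, first, only, none or still open, it means among the compounds named here.

Three analogues built on one shared core have been measured in a functional assay on MDA-MB-231 cells (Homo sapiens) for cytotoxicity, read by MTT assay, with a stated time of 72 h; on this read-out higher numbers stand for weaker inhibition and lower numbers for stronger inhibition. Compound 1 `Cc1ccc(F)cc1NC(=O)CN1CCN(c2nnc(Cc3ccccc3)c3ccccc23)CC1` gives 19200 nM, compound 2 `COc1ccc(NC(=O)CN2CCN(c3nnc(Cc4ccccc4)c4ccccc34)CC2)cc1OC` gives 32200 nM, and compound 3 `O=C(CN1CCN(c2nnc(Cc3ccccc3)c3ccccc23)CC1)Nc1ccc(F)c(F)c1` gives 2750 nM. Compound 3 stands lowest of the three: the step of a 7.0-fold lower number from compound 1 to compound 3 (0.84 log units; beyond the scatter) and the step of a 12-fold lower number from compound 2 to compound 3 (1.07 log units; beyond the scatter) both lie beyond the scatter, whereas the step of a 1.7-fold higher number from compound 1 to compound 2 (0.22 log units; within the scatter) does not, so compound 1 and compound 2 cannot be ordered against each other.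

Compound 4 `Cc1ccc(NC(=O)CN2CCN(c3nnc(Cc4ccccc4)c4ccccc34)CC2)c(C)c1` differs from compound 3 at one place only: 2,4-dimethylphenyl in place of 3,4-difluorophenyl on an amide-type nitrogen. The two steps that bear on this change both ran from an aryl ring carrying methyl or methoxy groups toward the 3,4-difluorophenyl ring, and both lowered the number, one modestly and one by a large margin. Compound 4 runs the other way, exchanging the 3,4-difluorophenyl for a ring that, like the ring of compound 1, carries methyl groups. A rise in the number beyond the scatter is therefore expected, most likely of modest size, bringing compound 4 back toward the region of compound 1 rather than compound 2. In this assay compound 4 is estimated at 14000 nM, with a range from 4000 nM to 45000 nM, which corresponds to an expected step of a 5.1-fold higher number from compound 3 to compound 4 (0.71 log units; beyond the scatter).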

Compound 4, half-maximal inhibitory concentration: 181000 nM
For compound 4 the middle estimate is 13-fold (1.11 log units) below the measured one, outside the stated range (above it).
By their numbers in this assay, from the lowest: compound 3; then compounds 1 and 2 (each within the scatter of the next); then compound 4.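

For the compounds shown here, the change to 2,4-dimethylphenyl on the amide-type nitrogen opens a much wider spread in this assay than the earlier compounds showed, giving a 66-fold higher number from compound 3 to compound 4 (1.82 log units; beyond the scatter) and so the largest step yet seen at this place. The new ring also separates from the two rings that could not be ordered against each other, with a 5.6-fold higher number from compound 2 to compound 4 (0.75 log units; beyond the scatter) and with a 9.4-fold higher number from compound 1 to compound 4 (0.97 log units; beyond the scatter) as well, so compound 4 has the highest number of the four by a margin beyond the scatter. Carrying methyl on the ring therefore does not by itself place a compound in the region of compound 1, and nothing shown here accounts for the size of these steps.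

The compounds shown leave open whether the high number of compound 4 follows the placing of its methyl groups or their presence alone, which a 3,4-dimethylphenyl group on the same nitrogen would address. On these data alone, how far the low number of compound 3 depends on fluorine also stays open, and a plain phenyl or a 3,4-dichlorophenyl group at this place would bear on that.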